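From a Short Hydroxy Chain to a Trifluoromethylphenyl Group

A few compounds are considered here, and "the series" means these few. Any claim that something is new, unique, unknown or untested is made for them only; others in the source may bear on it.

Compound 3 `COc1nc2ccc(Br)cc2cc1C(c1ccccc1)n1cc(CCO)nn1` was tested in an ADME assay on HEK293 cells (Homo sapiens) for cytotoxicity, read by sulforhodamine B assay, with a stated time of 48 h, tested at 10 uM (a higher number here means more inhibition at the concentration tested (going by the name of the read-out), a lower number less inhibition), where compound 3 gives 4.54%. Among the three measured compounds it stands second highest: compound 2 `COc1nc2ccc(Br)cc2cc1C(c1ccccc1)n1cc(-c2ccc(F)cc2)nn1` gives 4.04%, and the difference a number 0.5 percentage points higher from compound 2 to compound 3 (within the scatter) lies within the scatter, while compound 1 `COc1nc2ccc(Br)cc2cc1C(c1ccccc1)n1cc(CCCO)nn1` gives 27.4%, and the step of a number 22.9 percentage points lower from compound 1 to compound 3 (beyond the scatter) lies beyond it. Compound 4 `COc1nc2ccc(Br)cc2cc1C(c1ccccc1)n1cc(-c2ccccc2C(F)(F)F)nn1` differs from compound 3 by 2-(trifluoromethyl)phenyl in place of 2-hydroxyethyl on an aromatic carbon. For the measured compounds named here, the only measured guide is a number 0.5 percentage points higher from compound 2 to compound 3 (within the scatter), in which an aromatic ring was exchanged for this same short chain without moving the number beyond the scatter; the reverse exchange into a different aromatic ring is therefore expected to change little. Compound 4 is expected to give 6%, between 0% and 20%. This is expected to be a step of a number 1.5 percentage points higher from compound 3 to compound 4 (within the scatter), within the scatter.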

Compound 4, a percentage reported as inhibition, at one concentration (the size of the read-out at that concentration, not a potency): 14.3%
Compound 4: the middle estimate sits 8.3 percentage points below what was measured, and the stated range covers the measured number.
By their numbers in this assay, from the lowest: compounds 2, 3 and 4 (each within the scatter of the next, the first and the last beyond it); then compound 1.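

At this aromatic carbon, the kind of aryl group matters: the exchange of 4-fluorophenyl for 2-(trifluoromethyl)phenyl gives a number 10.3 percentage points higher from compound 2 to compound 4 (beyond the scatter) in this assay and so separates two compounds that both carry a six-membered aromatic ring. Against the chains, the picture differs, with a number 9.8 percentage points higher from compound 3 to compound 4 (within the scatter) for 2-hydroxyethyl but a number 13.1 percentage points lower from compound 1 to compound 4 (beyond the scatter) for 3-hydroxypropyl. No measurement shown accounts for these differences.

Still open, from the compounds shown here alone, is whether an amine, a carboxylic acid or a longer chain here would give a number closer to compound 1 or to compound 3. Also open, going by these compounds, is where plain phenyl would fall relative to compound 2 and compound 4.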